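Compound 1 to compound 4: a ring replaces the amide

This account rests on a few compounds, and the source may have more. Where it says the series, first, only, none or still open, it means among the compounds named here.

Measured in a physicochemical assay for solubility, in phosphate buffer, measured as thermodynamic solubility, at pH 7.4; a higher number here means a more soluble compound, a lower number a less soluble compound:
- compound 1 `CNC(=O)CCc1cn(-c2ccc(Br)cc2)nc1-c1ccc(Cl)cc1` gives < 5000 nM (a limit)
- compound 2 `CC(CC(=O)NS(C)(=O)=O)c1cn(-c2ccc(Cl)cc2)nc1-c1ccncc1` gives 170000 nM
- compound 3 `CS(=O)(=O)NC(=O)NCc1cn(-c2ccc(Cl)cc2)nc1-c1ccc(Cl)cc1` gives < 5000 nM (a limit)

Compound 1 has only a limit and no number, so its true position is open. It shares the limit of < 5000 nM in this assay, at which 2 of the 3 values shown sit, with one other compound. Compound 3 is that other compound, and its reading is likewise a limit. Compound 2 alone has a number, and it differs from compound 1 in more than one place, so it is a weak guide to a single change.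

Compound 4 `O=c1[nH]c(CCc2cn(-c3ccc(Br)cc3)nc2-c2ccc(Cl)cc2)no1` is not yet measured. The change is a group of 6 heavy atoms (2 carbon, 2 nitrogen, 2 oxygen; one five-membered aromatic ring with 3 hetero atoms) in place of a group of 4 heavy atoms (2 carbon, 1 nitrogen, 1 oxygen; no ring), on a saturated chain carbon, two bonds along the chain from an aromatic carbon and replaces methylcarbamoyl on a saturated chain carbon, two bonds along the chain from an aromatic carbon. Among the compounds with values here, no measured single-place step exists in this set to size it. The expected a number no lower from compound 1 to compound 4 (the limit leaves the size open) stays within the usual scatter in this assay and has no clear direction. This expectation leans on compound 3 (< 5000 nM) , which carries a different chain group and still gives only a limit. Another limit reading would not be surprising. For compound 4 the estimated value is 5000 nM and the expected range runs from 1500 nM to 30000 nM in this series.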

Compound 4, solubility: < 5000 nM
Compound 4: only a limit was reported (the forecaster's own chance of this, stated with the estimate: 60%); the middle value sits exactly at the limit.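

In this assay compound 4 gives < 5000 nM, a limit and not a number. Within the data shown here, compound 1 is likewise a limit, so no step between compound 1 and compound 4 can be read. The compounds shown leave open whether replacing methylcarbamoyl with the five-membered aromatic ring changes solubility at all, as most readings sit at one limit: the limit of < 5000 nM in this assay, at which 3 of the 4 values shown sit.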